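Swapping Methoxyphenyl for Furan on a Chalcone Amide

The source may report more compounds than this note shows. Statements on the series, on what has been measured and on what is new or still open speak of the compounds shown alone.

Compound 1 `COc1ccc(/C=C/C(=O)c2ccc(NC(=O)CO[N+](=O)[O-])cc2)cc1` gives 33% in a functional assay on the whole organism (strain albino) for inhibition, with Rattus norvegicus as the target, read by paw edema, with stated times of 30 min and 1 h, at a dose of 100 mg/kg by the oral route; on this read-out higher numbers stand for more inhibition at the one dose given (going by the name of the read-out) and lower numbers for less inhibition. Compound 2 `O=C(CO[N+](=O)[O-])Nc1ccc(C(=O)/C=C/c2ccco2)cc1` carries furan-2-yl in place of 4-methoxyphenyl on a double-bonded chain carbon bound to a double-bonded chain carbon and in this assay compound 2 gives 34%, a step of a number 1 percentage points higher from compound 1 to compound 2 (within the scatter). Compound 3 `COc1ccc(/C=C/C(=O)c2ccc(NC(=O)C(C)O[N+](=O)[O-])cc2)cc1` differs from compound 1 by methyl in place of hydrogen on a saturated chain carbon bound to a carbonyl carbon and an oxygen on an unsaturated carbon, and in this assay compound 3 gives 43%, a step of a number 10 percentage points higher from compound 1 to compound 3 (within the scatter). Compound 4 `CC(O[N+](=O)[O-])C(=O)Nc1ccc(C(=O)/C=C/c2ccco2)cc1`, not yet measured, differs from compound 3 by furan-2-yl in place of 4-methoxyphenyl on a double-bonded chain carbon bound to a double-bonded chain carbon. This is the same change already made from compound 1 to compound 2, occurring twice among these four compounds at the same place, with the two cores differing only by the methyl described above. Because that earlier change gave a number 1 percentage points higher from compound 1 to compound 2 (within the scatter), a step of similar size is expected: for compound 4 the expected step is a number 1 percentage points higher from compound 3 to compound 4 (within the scatter). Compound 4 is therefore estimated at 44%, most likely between 32% and 56%.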

Compound 4, a percentage reported as inhibition, in the whole organism at one dose (the size of the read-out at that dose, not a potency): 41%
Estimate against measurement, compound 4: 3 percentage points above; the range from low to high includes it.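

In this assay, the swap of 4-methoxyphenyl for furan-2-yl on the methyl-bearing core gives a number 2 percentage points lower from compound 3 to compound 4 (within the scatter), and the swap behaves alike on both cores: the same change on two cores in this assay, a number 1 percentage points higher (within the scatter) from compound 1 to compound 2 and a number 2 percentage points lower (within the scatter) from compound 3 to compound 4, 3 percentage points apart, within the scatter of two such steps. Adding the methyl gives a number 7 percentage points higher from compound 2 to compound 4 (within the scatter), and this change also behaves alike on both cores: the same change on two cores in this assay, a number 10 percentage points higher (within the scatter) from compound 1 to compound 3 and a number 7 percentage points higher (within the scatter) from compound 2 to compound 4, 3 percentage points apart, within the scatter of two such steps. All of these steps lie within the scatter, so the series shows that neither change made a readable difference on either core at this one dose, but it does not show that either change truly raises or lowers inhibition.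

Still open, from the compounds shown here alone, is whether a longer chain in place of the methyl, or a thiophene ring in place of furan-2-yl, would give a step beyond the scatter. Such a step would offer a firmer test of whether a change carries from one core to the other.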